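A few compounds are considered here, and "the series" means these few. Any claim that something is new, unique, unknown or untested is made for them only; others in the source may bear on it.

Measured so far:
Compound 1 `COC(=O)C1=C(C)NC(c2nccs2)=NC1(C)c1ccc(Cl)cc1` gives 14 ug/mL in a physicochemical assay for solubility, read by HPLC, in phosphate buffer, at pH 6.5; a higher number here means a more soluble compound, a lower number a less soluble compound.
Compound 2 `COC(=O)C1=C(CN2CCOCC2=O)NC(c2nccs2)=NC1(C)c1ccc(F)cc1` gives 440 ug/mL in this assay.

Compound 2 holds the higher of the two numbers; compound 1 sits well below it, and the gap between them lies beyond the usual scatter of this kind of measurement. Compound 3 `COC(=O)C1=C(COC2CCOC2)NC(c2nccs2)=NC1(C)c1ccc(F)cc1` has not yet been measured in this assay. It differs from compound 2 in one place: (oxolan-3-yl)oxy in place of 3-oxomorpholin-4-yl on a saturated chain carbon bound to a double-bonded ring carbon. For the measured compounds named here, nothing measured so far pairs two compounds that differ only in that way, so no measured step shows how far this exchange moves the number. On the two numbers that exist, compound 2 stands far above compound 1, and compound 3 keeps the same core with a group of similar size in the same place. The step from compound 2 to compound 3 in this assay is expected to be a moderate decrease, a 2.9-fold lower number from compound 2 to compound 3 (0.47 log units; beyond the scatter). Compound 3 is thus expected to give about 150 ug/mL, within a range from 50 ug/mL to 400 ug/mL.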

Compound 3, solubility: 30 ug/mL
Compound 3: middle estimate off by 5.0-fold (0.70 log units), on the high side, and the stated range ends above it.
By their numbers in this assay, from the lowest: compound 1; then compound 3; then compound 2.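

In this assay, the group on a saturated chain carbon bound to a double-bonded ring carbon matters greatly: (oxolan-3-yl)oxy in place of 3-oxomorpholin-4-yl gives a 15-fold lower number from compound 2 to compound 3 (1.17 log units; beyond the scatter). This large step comes between two groups with the same counts of hydrogen-bond donors and acceptors, so in this pair those counts do not track the number. The exchange changes the ring size, the ring hetero atoms and the double bond together, and no available evidence identifies which of these changes matters.

Going by these compounds, it remains open whether plain morpholin-4-yl, which lacks the carbonyl of 3-oxomorpholin-4-yl, would give a number nearer that of compound 2 or that of compound 3. On these data alone, how an open-chain amine such as dimethylamino would behave at this position also remains unknown.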